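The source may hold more compounds than are shown below. What is called first, only, known or untested is meant among the compounds shown, and "the series" means these compounds.

The measured compounds:

Compound 1, `O=C1/C(=C/c2ccc(F)cc2)CCC/C1=C\c1cccc([N+](=O)[O-])c1`, gives 5050 nM in a functional assay on CCRF-CEM cells (Homo sapiens) for cytotoxicity, with a stated time of 72 h; a higher number here means a weaker inhibitor, a lower number a stronger inhibitor.
Compound 2, `O=C1/C(=C/c2ccc(F)cc2)CCC/C1=C\c1ccc([N+](=O)[O-])cc1`, gives 18600 nM in this assay.
Compound 3, `O=C1/C(=C/c2ccc(Cl)cc2)CCC/C1=C\c1ccc([N+](=O)[O-])cc1`, gives 8180 nM in this assay.

All three share a core carrying two aromatic rings, one with a nitro group and one with a halogen. Compound 1 and compound 2 are built from the same atoms joined differently; the difference between their two cores is not broken down here. Compound 1 gives a lower number than compound 2, and that gap lies beyond the usual scatter, while compound 1 and compound 3 lie within the scatter of each other, so no order between those two is claimed.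

Compound 2 and compound 3 differ in one place, (chloro in place of fluoro on an aromatic carbon), and the step is a 2.3-fold lower number from compound 2 to compound 3 (0.36 log units; beyond the scatter), a modest change just beyond the scatter.

The unmeasured compound 4, `O=C1/C(=C/c2ccc(Cl)cc2)CCC/C1=C\c1cccc([N+](=O)[O-])c1`, stands to compound 1 as compound 3 stands to compound 2: chloro in place of fluoro on an aromatic carbon. The place is described in the same words in both cases, so this is the same change made on the core of compound 1 rather than the core of compound 2. Going by the values given here, only this one pair shows the change, so the expectation rests on a single step.

From compound 1 to compound 4 the expected step is a 2.2-fold lower number from compound 1 to compound 4 (0.34 log units; beyond the scatter), an estimate resting on the size of a 2.3-fold lower number from compound 2 to compound 3 (0.36 log units; beyond the scatter). Compound 4 is therefore estimated at 2300 nM in this assay, with a likely range from 1000 nM to 5500 nM.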

Compound 4, half-maximal inhibitory concentration: 1750 nM
Beside the measured number, compound 4's estimate is 1.3-fold (0.12 log units) above it, and the stated range covers the measured number.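

In this assay the swap from 4-fluorophenyl to 4-chlorophenyl on the core of compound 1 gives a 2.9-fold lower number from compound 1 to compound 4 (0.46 log units; beyond the scatter) as a modest change in the same direction as on the core of compound 2. The two steps agree in direction, and their sizes cannot be told apart, so in this small set the change carries from one core to the other: the same change on two cores in this assay, a 2.3-fold lower number (0.36 log units; beyond the scatter) from compound 2 to compound 3 and a 2.9-fold lower number (0.46 log units; beyond the scatter) from compound 1 to compound 4, 1.3-fold (0.10 log units) apart, within the scatter of two such steps. Going by these compounds alone, this rests on only two pairs of compounds, both with a nitro group on the second aromatic ring, so it does not show that the step would hold on a core without that group, and it says nothing about why chloro gives the lower number.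

The compounds shown leave open how other groups on the same aromatic carbon would behave, such as bromo, methyl or methoxy, and whether the step would keep its size with any of them. They also leave open what would happen if the nitro group gave way to an amine or a carboxylic acid, and whether the chloro step would survive that exchange.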